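Cytotoxicity notes: thiophene in place of pyridine on the core

The source may report more compounds than this note shows. Statements on the series, on what has been measured and on what is new or still open speak of the compounds shown alone.

Measured so far:
- compound 1 `Oc1ccc(-c2cc(-c3cccc(Cl)c3)nc(-c3ccccn3)c2)cc1`: 25400 nM
- compound 2 `Oc1cccc(-c2cc(-c3cccc(Cl)c3)nc(-c3ccccn3)c2)c1`: "not determined" (no result reported)
- compound 3 `Oc1cccc(-c2cc(-c3ccccn3)nc(-c3ccccc3Cl)c2)c1`: "not determined" (no result reported)

In an ADME assay on HEK293 cells (Homo sapiens) for cytotoxicity, read by CCK-8 assay and cell counting, with a stated time of 2 days (on this read-out lower numbers stand for stronger inhibition and higher numbers for weaker inhibition), compound 1 gives 25400 nM. For compound 2 this assay holds no single number; the entry reads "not determined" (no result reported). Compound 3 is a further entry without a number, given as "not determined" (no result reported). Among the compounds with values here, compound 2 therefore stands nowhere on a scale of numbers here; the only measured figure in the set is the one for compound 1, which shares its pattern of substituents apart from where the hydroxyl sits on the phenyl ring.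

Compound 4 `Oc1cccc(-c2cc(-c3cccc(Cl)c3)nc(-c3cccs3)c2)c1` differs from compound 2 in one place: thiophen-2-yl in place of pyridin-2-yl on an aromatic carbon. Within the data shown here, no step between measured compounds exists for this change, so nothing tells its size. Among the measured compounds shown here, with only the single weak value of compound 1 as a reference, a step in this assay no larger than the usual scatter is expected, in no firm direction. For compound 4 a half-maximal inhibitory concentration of about 22000 nM is estimated, in the range 6000 nM to 80000 nM.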

Compound 4, half-maximal inhibitory concentration: 3150 nM
For compound 4 the middle estimate is 7.0-fold (0.84 log units) above the measured one; the measured number lies below the stated range.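

Within the data shown here, the entry for compound 2 holds no single number, and no step to compound 4 can be read from it. From the compounds shown here alone, the size and direction of the change from pyridin-2-yl to thiophen-2-yl remain open. No evidence at hand bears on this result.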